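Cytotoxicity of cyano-benzamide sulfonamides in a cell assay

The compounds below may be only part of what the source reports. "The series", "measured", "known", "first", "only" and "open" are said of these compounds alone.

Measured compounds and their values:
- compound 1, `COc1cc(NC(=O)c2ccc(C#N)cc2)ccc1NS(C)(=O)=O`: > 250000 nM
- compound 2, `CCS(=O)(=O)Nc1ccc(NC(=O)c2ccc(C#N)cc2)cc1OC`: > 250000 nM
- compound 3, `CS(=O)(=O)Nc1ccc(NC(=O)c2ccc(C#N)cc2)cc1Cl`: > 250000 nM

In an ADME assay on HEK293 cells (Homo sapiens) for cytotoxicity, read by MTT assay, with a stated time of 48 h (on this read-out higher numbers stand for weaker inhibition and lower numbers for stronger inhibition), compound 1 reaches only a limit of the assay, > 250000 nM. Compound 2 likewise reaches only a limit, > 250000 nM. Compound 3 also stops at a limit, > 250000 nM; all three values sit at the same limit, as noted in the limit of > 250000 nM in this assay, at which 3 of the 3 values shown sit. Compound 4, `CCS(=O)(=O)Nc1ccc(NC(=O)c2ccc(C#N)cc2)cc1Cl`, is not yet measured. It differs from compound 3 by methyl in place of hydrogen on a saturated chain carbon bound to a sulfonyl sulfur. Going by the values given here, the steps that bear on this change are a step that the two limits leave unreadable from compound 1 to compound 2 and a step that the two limits leave unreadable from compound 1 to compound 3, both of which remain unreadable because each end sits at the limit (the limit of > 250000 nM in this assay, at which 3 of the 3 values shown sit). Among the compounds with values here, with no readable step among the measured compounds, and every value at the limit, compound 4 is expected to sit at the same limit as well, so the step that the limit leaves unreadable from compound 3 to compound 4 is estimated to be no step that can be read. Compound 4 is therefore expected to give an estimated 300000 nM in this assay, within the range 150000 nM to 600000 nM.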

Compound 4, half-maximal inhibitory concentration: > 250000 nM
Compound 4 ended at the assay's limit; the forecaster's own chance of this, stated with the estimate: 90%; the middle value is on the limit's open side.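

In this assay compound 4 gives > 250000 nM, which is a limit. The steps from compound 3 and from compound 2 to compound 4 therefore cannot be read: the limit of > 250000 nM in this assay, at which 4 of the 4 values shown sit. The compounds shown leave open whether these four differ in cytotoxicity at all.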